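The source may hold more compounds than are shown below. What is called first, only, known or untested is meant among the compounds shown, and "the series" means these compounds.

Within the data shown here, compound 1 `Nc1sc(-c2ccc(Cl)cc2)c(-c2ccc(Cl)cc2)c1C(=O)N1CCCC1` gives 6220 nM in a functional assay on PC-3 cells (Homo sapiens) for inhibition, read by sulforhodamine B assay, with a stated time of 72 h (a higher number here means a weaker inhibitor, a lower number a stronger inhibitor), the lowest of the three numbers measured so far. Compound 2 `CC1CN(C(=O)c2c(N)sc(-c3ccc(Cl)cc3)c2-c2ccc(Cl)cc2)CCN1` gives 7210 nM, and compound 3 `CC(C)CNC(=O)c1c(N)sc(-c2ccc(Cl)cc2)c1-c1ccc(Cl)cc1` gives 13200 nM. Both measured steps from compound 1 alter the group on the carbonyl carbon: a 1.2-fold higher number from compound 1 to compound 2 (0.06 log units; within the scatter), and a 2.1-fold higher number from compound 1 to compound 3 (0.33 log units; beyond the scatter); between those two, a 1.8-fold higher number from compound 2 to compound 3 (0.26 log units; within the scatter). Compound 4 `Nc1sc(-c2ccc(Cl)cc2)c(-c2ccc(Cl)cc2)c1C(=O)N1CCOCC1` differs from compound 1 by morpholin-4-yl in place of pyrrolidin-1-yl on a carbonyl carbon. Such a ring-for-ring exchange resembles the step to compound 2 more than the step to compound 3, so in this assay any change is expected to be at most modest, most likely a somewhat higher number and possibly none beyond the scatter. Compound 4 is therefore estimated at 7500 nM, within a range from 4000 nM to 14000 nM, meaning a 1.2-fold higher number from compound 1 to compound 4 (0.08 log units; within the scatter).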

Compound 4, half-maximal inhibitory concentration: 11700 nM
For compound 4 the middle estimate is 1.6-fold (0.19 log units) below the measured one; low and high end bracket the measured number.
By their numbers in this assay, from the lowest: compounds 1, 2, 4 and 3 (each within the scatter of the next, the first and the last beyond it).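

In this assay, the exchange of pyrrolidin-1-yl for morpholin-4-yl on the carbonyl carbon gives a 1.9-fold higher number from compound 1 to compound 4 (0.27 log units; within the scatter). Compound 4 also stands within the scatter of the other two, with a 1.6-fold higher number from compound 2 to compound 4 (0.21 log units; within the scatter) and a 1.1-fold lower number from compound 3 to compound 4 (0.05 log units; within the scatter), so the added ring oxygen, a hydrogen-bond acceptor, does not separate it from any of them. Nothing shown explains these numbers. Still open, from the compounds shown here alone, is whether a carboxylic acid or a longer chain on this carbonyl carbon would leave this narrow band.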